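The compounds below may be only part of what the source reports. "The series", "measured", "known", "first", "only" and "open" are said of these compounds alone.

Three related compounds have been measured in a functional assay on MCF7 cells (Homo sapiens) for inhibition, in the absence of a further agent; a lower number here means a stronger inhibitor, a higher number a weaker inhibitor. Compound 2 (`Nc1ccc(-c2cc(=O)c3c(N)ccc(F)c3o2)cc1`) gives 6.9 nM, compound 3 (`Nc1ccc(-c2cc(=O)c3c(N)c(F)cc(F)c3o2)cc1`) gives 6 nM and compound 1 (`Nc1c(F)cc(-c2cc(=O)c3c(N)c(F)cc(F)c3o2)cc1F`) gives 4 nM. Compound 2 therefore stands within the scatter of both other compounds, and the three values cannot be ranked. Compound 4 (`Nc1ccc(-c2cc(=O)c3c(N)ccc(O)c3o2)cc1`) has not yet been measured. It differs from compound 2 by one change: hydroxy in place of fluoro on an aromatic carbon. In words, this is hydroxy in place of fluoro on an aromatic carbon.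

For the measured compounds named here, the only measured step between two single-change neighbours is a 1.2-fold lower number from compound 2 to compound 3 (0.06 log units; within the scatter). It adds a fluoro in place of hydrogen, stays within the scatter and leaves the fluoro in question untouched, so it gives only weak guidance. All three measured compounds carry fluoro on that carbon, and none carries hydroxy there, so the data do not measure this replacement. A modest move towards a weaker inhibitor is tentatively expected, with an estimated step of a 2.6-fold higher number from compound 2 to compound 4 (0.42 log units; beyond the scatter). Compound 4 is estimated at 18 nM, with an expected range from 4 nM to 90 nM.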

Compound 4, half-maximal inhibitory concentration: 5300 nM
Compound 4: middle estimate off by 290-fold (2.47 log units), on the low side; the measured number lies above the stated range.
By their numbers in this assay, from the lowest: compounds 1, 3 and 2 (each within the scatter of the next); then compound 4.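

The carbon para to an amino group proved far from indifferent in this assay: hydroxy in place of fluoro gives a 770-fold higher number from compound 2 to compound 4 (2.89 log units; beyond the scatter), although both groups are single heavy atoms. For the compounds shown here, the earlier compounds all carry fluoro on this carbon and sit within the scatter of one another, and the one step among them, a 1.2-fold lower number from compound 2 to compound 3 (0.06 log units; within the scatter), changes a different place, so none of them showed how much depends on the group held here. Nothing available accounts for the size of this step.

The compounds shown leave open whether the loss of fluoro or the arrival of hydroxy drives the step, which plain hydrogen, chloro or methoxy on the same carbon would help to separate. They also leave open whether the same replacement would give a step of similar size starting from compound 3 or compound 1.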